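Swapping the anilide ring: compound 3 after compound 2

The source may hold more compounds than are shown below. What is called first, only, known or untested is meant among the compounds shown, and "the series" means these compounds.

compound 1 `O=C(COc1ccc(/C=C2\SC(=O)NC2=O)cc1)Nc1ccc(F)cc1` — > 100000 nM
compound 2 `O=C(COc1ccc(/C=C2\SC(=O)NC2=O)cc1)Nc1ccc(F)cc1F` — > 100000 nM

Compound 1 `O=C(COc1ccc(/C=C2\SC(=O)NC2=O)cc1)Nc1ccc(F)cc1` and compound 2 `O=C(COc1ccc(/C=C2\SC(=O)NC2=O)cc1)Nc1ccc(F)cc1F` share one core and differ only by a fluoro in place of hydrogen on an aromatic carbon. In a functional assay on KB cells (Homo sapiens) for inhibition (on this read-out higher numbers stand for weaker inhibition of growth and lower numbers for stronger inhibition of growth), compound 1 gives > 100000 nM, which is a limit of the assay and not a number. In this assay compound 2 also gives > 100000 nM, again a limit. The step that the two limits leave unreadable from compound 1 to compound 2 is therefore unreadable in size, since both values sit at the limit of > 100000 nM in this assay, at which 2 of the 2 values shown sit. Compound 2 thus stands at the limit, with no number of its own.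

Compound 3 `Cc1ccc(NC(=O)COc2ccc(/C=C3\SC(=O)NC3=O)cc2)cc1Cl` is not yet measured. It differs from compound 2 by 3-chloro-4-methylphenyl in place of 2,4-difluorophenyl on an amide-type nitrogen. For the measured compounds named here, no measured step covers this exchange, and the single measured step leaves its own size unreadable. With both known values at the limit, compound 3 is expected most likely to stay at the limit too, so the estimated step that the limit leaves unreadable from compound 2 to compound 3 is taken as none beyond the scatter. Compound 3 is estimated at 150000 nM, within 30000 nM to 600000 nM.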

Compound 3, concentration for 50% growth inhibition: 99600 nM
Compound 3: middle estimate off by 1.5-fold (0.18 log units), on the high side; low and high end bracket the measured number.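

In this assay, for the compounds shown here, compound 3 gives 99600 nM, the only number among the three compounds, so 3-chloro-4-methylphenyl on the amide-type nitrogen gives a read-out that neither 4-fluorophenyl nor 2,4-difluorophenyl gave. Compound 1 and compound 2 each stand at a limit of the assay and not at a number: the limit of > 100000 nM in this assay, at which 2 of the 3 values shown sit. The steps from each of them to compound 3 cannot be read in size, and compound 3 may lie close to them or far from them.

The compounds shown give a number no higher from compound 2 to compound 3 (the limit leaves the size open) and a number no higher from compound 1 to compound 3 (the limit leaves the size open), but they leave open whether the chloro or the methyl alone would give a number on this ring. They also leave open how a methoxy, a nitrile or a carboxylic acid on this ring would read in this assay.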